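Amide N-methylation with chain shortening in the furoyl series

The compounds below may be only part of what the source reports. "The series", "measured", "known", "first", "only" and "open" are said of these compounds alone.

For the measured compounds named here, compound 2 `COc1cc2nc(NCCCCCCCCNC(=O)c3ccco3)nc(N)c2cc1OC` stands at the highest number of the three measured members: in a functional assay for antagonist activity at Adrenergic receptor alpha-1 (Rattus norvegicus) (on this read-out higher numbers stand for weaker binding and lower numbers for tighter binding), compound 2 gives 60.3 nM. Its nearest neighbour is compound 1 `COc1cc2nc(NCCCCCCCNC(=O)c3ccco3)nc(N)c2cc1OC`, which in this assay gives 28.8 nM; the furthest is compound 3 `COc1cc2nc(N(C)CCCCN(C)C(=O)c3ccco3)nc(N)c2cc1OC`, which in this assay gives 7.08 nM.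

The change now followed leads to compound 4 `COc1cc2nc(NCCCCCCN(C)C(=O)c3ccco3)nc(N)c2cc1OC`: ((furan-2-yl)carbonyl)(methyl)amino in place of 2-(((furan-2-yl)carbonyl)amino)ethyl on a saturated chain carbon, six bonds along the chain from a nitrogen on an aromatic ring. It combines a shortening of the chain with methylation of the amide nitrogen.

Going by the values given here, only one measured step bears directly on it: chain lengthening, a 2.1-fold higher number from compound 1 to compound 2 (0.32 log units; beyond the scatter), moved the number upward. The reverse direction, shortening, would therefore be expected to move it downward. Among the compounds with values here, compound 3 carries the shortest chain and methyl groups on both nitrogens and gives the lowest number of the three, which points the same way, though no single-change step connects it to compound 2.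

On this basis the step from compound 2 to compound 4 is expected to be a 3.4-fold lower number from compound 2 to compound 4 (0.53 log units; beyond the scatter) in this assay. Compound 4 is therefore estimated at 18 nM in this assay, within a range from 7 nM to 45 nM.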

Compound 4, dissociation constant: 6.76 nM
Compound 4: the middle estimate sits 2.7-fold (0.43 log units) above what was measured; measured number below the stated range.
By their numbers in this assay, from the lowest: compounds 4 and 3 (each within the scatter of the next); then compound 1; then compound 2.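

In this assay, ((furan-2-yl)carbonyl)(methyl)amino in place of 2-(((furan-2-yl)carbonyl)amino)ethyl gives an 8.9-fold lower number from compound 2 to compound 4 (0.95 log units; beyond the scatter), and the corresponding replacement against the next shorter chain gives a 4.3-fold lower number from compound 1 to compound 4 (0.63 log units; beyond the scatter), so the N-methylated amide on the shorter chain lies beyond the scatter from both secondary amides. For the compounds shown here, both steps are larger in printed size than the only step that changes chain length without methylation, a 2.1-fold higher number from compound 1 to compound 2 (0.32 log units; beyond the scatter), and the entering group counts 0 hydrogen-bond donors against 1 in the group it replaces. Nothing measured here explains these steps.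

Chain shortening and loss of the amide hydrogen arrive together in compound 4, so the share of each remains unresolved until an N-methyl amide is compared with a secondary amide at the same chain length. Also open, from the compounds shown here alone, is whether an N-ethyl amide, or a benzoyl group in place of the furan-2-yl carbonyl, would follow the same course on this chain.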